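Swapping the Methylphenyl Ring for Pyridin-4-yl

The source may hold more compounds than are shown below. What is called first, only, known or untested is meant among the compounds shown, and "the series" means these compounds.

Of the compounds shown here, three built on one shared core have been measured in a functional assay on HeLa cells (Homo sapiens) for cytotoxicity, read by MTT assay, with a stated time of 24 h; a higher number here means a weaker inhibitor, a lower number a stronger inhibitor. Compound 1 `COc1ccc(/C=C2\SC(=O)N(Cc3ccc(C(=O)O)cc3)C2=O)cc1` gives 40000 nM in this assay. Compound 2 `O=C(O)c1ccc(CN2C(=O)S/C(=C\c3ccccc3)C2=O)cc1` gives 72000 nM, and compound 3 `Cc1ccc(/C=C2\SC(=O)N(Cc3ccc(C(=O)O)cc3)C2=O)cc1` gives 68000 nM. Compound 3 holds the second highest of the three numbers; its nearest neighbour is compound 2 and its furthest is compound 1, yet every step among the three lies within the scatter: a 1.8-fold higher number from compound 1 to compound 2 (0.26 log units; within the scatter), a 1.7-fold higher number from compound 1 to compound 3 (0.23 log units; within the scatter) and a 1.1-fold lower number from compound 2 to compound 3 (0.02 log units; within the scatter).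

Compound 4 `O=C(O)c1ccc(CN2C(=O)S/C(=C\c3ccncc3)C2=O)cc1` differs from compound 3 in one place: pyridin-4-yl in place of 4-methylphenyl on a double-bonded chain carbon bound to a double-bonded ring carbon. Among the measured compounds shown here, no measured step exchanges the ring itself; each of the three measured steps only swaps a group on an aromatic carbon, and none moved the number beyond the scatter. For the measured compounds named here, with nothing among the measured compounds pointing to a shift in either direction, the expected step is a 1.0-fold lower number from compound 3 to compound 4 (0.02 log units; within the scatter), that is, none beyond the scatter. Compound 4 is accordingly estimated at 65000 nM in this assay, with a range from 30000 nM to 150000 nM.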

Compound 4, half-maximal inhibitory concentration: 60000 nM
The estimate for compound 4 lay 1.1-fold (0.03 log units) above the measured number; the measured number falls inside the stated range.
By their numbers in this assay, from the lowest: compounds 1, 4, 3 and 2 (each within the scatter of the next).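

Compound 4 alone among the four carries a ring with a hetero atom on the double-bonded chain carbon bound to a double-bonded ring carbon, and this adds one hydrogen-bond acceptor to the group there. In this assay, the exchange stays within the scatter against each of the three carbon-only rings: a 1.1-fold lower number from compound 3 to compound 4 (0.05 log units; within the scatter), a 1.2-fold lower number from compound 2 to compound 4 (0.08 log units; within the scatter) and a 1.5-fold higher number from compound 1 to compound 4 (0.18 log units; within the scatter). So, across these four compounds, replacing the whole ring at this place has moved the number no further beyond the scatter than swapping a group on an aromatic carbon did, and no supporting data bear on this result.

The compounds shown leave open whether a pyridin-3-yl group at this place would also stay within the scatter. They also do not tell whether a phenyl ring bearing an amine would give a number beyond it.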